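Series notes: 4-methylphenyl to 2,4-dimethylphenyl

The source may hold more compounds than are shown below. What is called first, only, known or untested is meant among the compounds shown, and "the series" means these compounds.

In a functional assay on HCT-116 cells (Homo sapiens) for antiproliferative activity, read by MTT assay, with a stated time of 72 h (on this read-out higher numbers stand for weaker inhibition and lower numbers for stronger inhibition), compound 1 `Nc1nc(N)c2cc(CSC(=S)N3CCN(C4CCCCC4)CC3)ccc2n1` reads 8400 nM while compound 2 `Nc1nc(N)c2cc(CSC(=S)N3CCN(c4ccc(O)cc4)CC3)ccc2n1` reads 5980 nM and compound 3 `Cc1ccc(N2CCN(C(=S)SCc3ccc4nc(N)nc(N)c4c3)CC2)cc1` reads 5510 nM on the same scale. Compound 3 cannot be separated from the other two, as all three numbers lie within the scatter. Compound 4 `Cc1ccc(N2CCN(C(=S)SCc3ccc4nc(N)nc(N)c4c3)CC2)c(C)c1` differs from compound 3 in one place: methyl in place of hydrogen on an aromatic carbon with methyl in place of hydrogen on an aromatic carbon, ortho to a large group and meta to a methyl group, so 4-methylphenyl becomes 2,4-dimethylphenyl. Within the data shown here, no measured step adds a methyl at this place. The closest evidence is a 1.1-fold lower number from compound 2 to compound 3 (0.04 log units; within the scatter) for methyl in place of hydroxy on an aromatic carbon. Replacing cyclohexyl on the amine nitrogen gives a 1.4-fold lower number from compound 1 to compound 2 (0.15 log units; within the scatter) and a 1.5-fold lower number from compound 1 to compound 3 (0.18 log units; within the scatter) and these also stay within the scatter. In this assay no step beyond the scatter is expected, and the estimated step is a 1.1-fold lower number from compound 3 to compound 4 (0.04 log units; within the scatter) in size. The estimate for compound 4 is 5000 nM with an expected range from 2400 nM to 10000 nM in this read-out.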

Compound 4, half-maximal inhibitory concentration: 4070 nM
Beside the measured number, compound 4's estimate is 1.2-fold (0.09 log units) above it; low and high end bracket the measured number.
By their numbers in this assay, from the lowest: compounds 4, 3, 2 and 1 (each within the scatter of the next, the first and the last beyond it).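

In this assay a methyl is accepted on this aromatic carbon, ortho to a large group and meta to a methyl group: a 1.4-fold lower number from compound 3 to compound 4 (0.13 log units; within the scatter) stays within the scatter, as does a 1.5-fold lower number from compound 2 to compound 4 (0.17 log units; within the scatter) on exchanging 4-hydroxyphenyl for 2,4-dimethylphenyl. Among these compounds, the only step to pass the scatter is a 2.1-fold lower number from compound 1 to compound 4 (0.31 log units; beyond the scatter) in a modest move, which gives the first separation within the set, while compound 2 and compound 3 still cannot be told apart from compound 1. No supporting data explain this separation.

Open, from the compounds shown here alone, is what a methoxy group, a chlorine atom or an amine would do on the same carbon. Also open, going by these compounds, is how a lone methyl there would read with no 4-methyl group on the ring.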